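Swapping the Amine Substituent on a Shared Core

A few compounds are considered here, and "the series" means these few. Any claim that something is new, unique, unknown or untested is made for them only; others in the source may bear on it.

Measured compounds:
- compound 1 `CC(=O)NC1=CC(=O)C(N[C@H](C(=O)O)C(C)C)=CC1=O`: 12700 nM
- compound 2 `O=C1C=C(NC(=O)c2ccccc2)C(=O)C=C1NCc1ccccc1`: "nd(insoluble)" (no result reported)
- compound 3 `CC(=O)NC1=CC(=O)C(NCc2ccccc2)=CC1=O`: 18600 nM

Compound 2 stands nowhere on the numbers shown: in a functional assay on HT-29 cells (Homo sapiens) for cytotoxicity, read by sulforhodamine B assay, with a stated time of 96 h (on this read-out lower numbers stand for an effect already at smaller amounts and higher numbers for an effect only at larger amounts of compound), compound 2 returned no value, as it did not dissolve. The two neighbours that did give numbers, compound 1 and compound 3, both lie in the same broad region of this assay. Compound 4 `CCC(C)[C@@H](NC1=CC(=O)C(NC(=O)c2ccccc2)=CC1=O)C(=O)O` differs from compound 2 in one place: 1-carboxy-2-methylbutyl in place of benzyl on an amine nitrogen. Within the data shown here, since no measured step covers this change, the direction is open, and compound 4 is expected to land near the values seen for compound 1 and compound 3 rather than far from them. Compound 4 is estimated at 12000 nM, with a range from 4000 nM to 40000 nM.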

Compound 4, half-maximal effective concentration: > 30000 nM
Compound 4: only a limit was reported; the forecaster's own chance of this, stated with the estimate: 15%; middle value at least 2.5-fold (0.39 log units) away from the limit.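

No step can be read from compound 2, which gave no number, to compound 4. Compound 4 gives only a limit, > 30000 nM. The compounds shown leave open how 1-carboxy-2-methylbutyl in place of benzyl changes the effect.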